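Hydrogen in place of hydroxy on compound 1

The source may report more compounds than this note shows. Statements on the series, on what has been measured and on what is new or still open speak of the compounds shown alone.

In a functional assay on MDA-MB-231 cells (Homo sapiens) for cytotoxicity, read by MTT assay (on this read-out higher numbers stand for weaker inhibition and lower numbers for stronger inhibition), compound 1 `COc1ccc(-n2cc(-c3ccc(OC)c(OC)c3)nn2)cc1O` gives > 1000 nM as a limit and not a number. Compound 2 `COc1ccc(-c2cn(-c3cc(OC)c(OC)c(OC)c3)nn2)cc1O` gives > 10000 nM as a limit too. Compound 1 therefore stands on a limit only, and the two compounds cannot be ordered. Compound 3 `COc1ccc(-n2cc(-c3ccc(OC)c(OC)c3)nn2)cc1` differs from compound 1 by hydrogen in place of hydroxy on an aromatic carbon with hydrogen in place of hydroxy on an aromatic carbon, ortho to a methoxy group and meta to a large group. Within the data shown here, no measured pair shows this change. The step that the limit leaves unreadable from compound 1 to compound 3 is expected to be modest and towards weaker inhibition in this assay and could again end at a limit. Compound 3 is expected at 6000 nM with an estimated range from 1500 nM to 30000 nM in this series.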

Compound 3, half-maximal inhibitory concentration: > 100 nM
Compound 3 gave a limit, no number; the forecaster's own chance of this, stated with the estimate: 65%; the middle value lies beyond the limit too.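

Among these compounds, compound 1 and compound 3 both stand only on limits in this assay, so no step between them can be read. The compounds shown leave open whether hydrogen in place of hydroxy changes inhibition at all.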